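A few compounds are considered here, and "the series" means these few. Any claim that something is new, unique, unknown or untested is made for them only; others in the source may bear on it.

Measured in a functional assay on HCT-116 cells (Homo sapiens) for antiproliferative activity, read by MTT assay, with a stated time of 48 h; on this read-out lower numbers stand for stronger inhibition and higher numbers for weaker inhibition:
- compound 1 `CC(CCO)n1cnc2c(Cl)nc(F)nc21`: 19800 nM
- compound 2 `CC(CCO)n1cnc2c(Cl)ncnc21`: > 50000 nM (a limit of the assay, not a number)
- compound 3 `CCCCC(CCO)n1cnc2c(Cl)nc(Cl)nc21`: 15500 nM

Among the measured compounds shown here, compound 1 and compound 3 are the only two with true numbers, and these lie within the usual scatter of each other, so neither ranks ahead.

Compound 4 `CCCCCCCCC(CCO)n1cnc2c(Cl)nc(F)nc21` alters compound 1 on its chain: heptyl in place of hydrogen on a saturated chain carbon, two bonds along the chain from an aromatic nitrogen. For the measured compounds named here, the only measured step, an at least 2.5-fold higher number from compound 1 to compound 2 (0.40 log units; beyond the scatter), concerns an aromatic carbon instead, so it says little about this change. Compound 3, at 15500 nM, stays close to compound 1, so no step beyond the scatter is expected in this assay, although this expectation is loose. The expected change is a 1.7-fold lower number from compound 1 to compound 4 (0.22 log units; within the scatter). For compound 4 the estimated value is 12000 nM, with an expected range of 3000 nM to 35000 nM.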

Compound 4, half-maximal inhibitory concentration: 24200 nM
The estimate for compound 4 lay 2.0-fold (0.30 log units) below the measured number; measured number inside the range.
By their numbers in this assay, from the lowest: compounds 3, 1 and 4 (each within the scatter of the next). At a limit, above all of these: compound 2.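

In this assay, putting heptyl on the saturated chain carbon, two bonds along the chain from an aromatic nitrogen, gives a 1.2-fold higher number from compound 1 to compound 4 (0.09 log units; within the scatter), so this position accepts a chain of that size without a step beyond the scatter. Among the compounds shown here, the one earlier step concerned an aromatic carbon, which makes this the first single-change reading at the chain. Nothing measured here accounts for this result. On these data alone, whether an amine, a carboxylic acid or a phenyl ring at this position would give a step beyond the scatter remains open.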